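Lengthening an alkenyl chain: from compound 3 to compound 4

A few compounds are considered here, and "the series" means these few. Any claim that something is new, unique, unknown or untested is made for them only; others in the source may bear on it.

Measured so far in a functional assay on T98G cells (Homo sapiens) for inhibition, read by colorimetric assay and MTT assay, with a stated time of 72 h; on this read-out higher numbers stand for weaker inhibition and lower numbers for stronger inhibition:
- compound 1 `Cn1c2cnc1OCCCCCCCCOc1ccc(F)cc1-2` gives 77000 nM
- compound 2 `C=CCCCCOc1cc2ccccc2cc1-c1cnc(OCCC=C)n1C` gives 32000 nM
- compound 3 `C=CCCCCOc1ccccc1-c1cnc(OCCCC=C)n1C` gives 3000 nM

Compound 3 holds the lowest of the three numbers and so shows the strongest inhibition of the set, clear of the scatter against both others. Its nearest neighbour is compound 2 and its furthest is compound 1.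

Compound 4 `C=CCCCCCOc1ncc(-c2ccccc2OCCCCC=C)n1C` has not yet been measured. It differs from compound 3 by but-3-en-1-yl in place of vinyl on a saturated chain carbon, three bonds along the chain from an oxygen on an aromatic ring. The same difference can be read as pent-4-en-1-yl to hept-6-en-1-yl.

Within the data shown here, no measured pair isolates a change of this kind, so the expectation rests on only three values. A small move toward a higher number is expected in this assay, possibly not beyond the scatter. The estimated size is a 1.7-fold higher number from compound 3 to compound 4 (0.22 log units; within the scatter) in this read-out. Compound 4 is estimated at 5000 nM (expected range 1500 nM to 17000 nM).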

Compound 4, half-maximal inhibitory concentration: 63000 nM
The estimate for compound 4 lay 13-fold (1.10 log units) below the measured number; the whole stated range lies below it.
By their numbers in this assay, from the lowest: compound 3; then compounds 2, 4 and 1 (each within the scatter of the next, the first and the last beyond it).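

Among these compounds, this is the first pair that isolates a single change, and it shows that inhibition in this assay is sensitive to chain length at this position. Replacing vinyl with but-3-en-1-yl on a saturated chain carbon, three bonds along the chain from an oxygen on an aromatic ring, gives a large loss of inhibition, a 21-fold higher number from compound 3 to compound 4 (1.32 log units; beyond the scatter), even though both groups are hydrocarbon with one double bond outside aromatic rings and neither has a hydrogen-bond donor or acceptor. No available data explain this loss.

The compounds shown leave open whether the loss builds gradually with length or sets in abruptly, since allyl, the intermediate length, is absent from this set. They also leave open whether a saturated propyl chain, or an amine or carboxylic acid at the chain end, would be accepted at this position.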